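The source may hold more compounds than are shown below. What is called first, only, known or untested is meant among the compounds shown, and "the series" means these compounds.

Compound 3 `OC[C@H]1OC(n2cnc3c(Cl)nccc32)[C@H](O)[C@@H]1O` stands highest of the three numbers in a functional assay (Homo sapiens) for inhibition of Nucleic Acid, tested at 100 uM; a lower number here means less inhibition, a higher number more inhibition at the concentration tested (going by the name of the read-out): compound 3 gives 76%, while compound 2 `OC[C@H]1OC(n2cnc3c(SCc4ccccc4)nccc32)[C@H](O)[C@@H]1O` gives 30% and compound 1 `OC[C@H]1OC(n2cnc3c(S)nccc32)[C@H](O)[C@@H]1O` gives 6%. Compound 4 `CN(C)c1nccc2c1ncn2C1O[C@H](CO)[C@@H](O)[C@H]1O` differs from compound 3 by dimethylamino in place of chloro on an aromatic carbon. For the measured compounds named here, the steps that bear on this are those into chloro at the same aromatic carbon: a number 70 percentage points higher from compound 1 to compound 3 (beyond the scatter) and a number 46 percentage points higher from compound 2 to compound 3 (beyond the scatter), both large; the step of a number 24 percentage points higher from compound 1 to compound 2 (beyond the scatter) changes only the group on the sulfur and is modest. Going by the values given here, every measured replacement leaving chloro as the group on that carbon raised the read-out, so removing chloro is expected to lower it, though no step into dimethylamino exists, so the size is uncertain. The step of a number 36 percentage points lower from compound 3 to compound 4 (beyond the scatter) is expected, giving compound 4 an estimated 40% in this assay, ranging from 10% to 72%.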

Compound 4, a percentage reported as inhibition, at one concentration (the size of the read-out at that concentration, not a potency): 0%
For compound 4 the middle estimate is 40 percentage points above the measured one; the measured number lies below the stated range.
By their numbers in this assay, from the lowest: compounds 4 and 1 (each within the scatter of the next); then compound 2; then compound 3.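

In this assay, a number 76 percentage points lower from compound 3 to compound 4 (beyond the scatter) when dimethylamino replaces chloro, so the read-out at this aromatic carbon can be lost entirely, not just reduced. Dimethylamino also compares unfavourably with benzylsulfanyl, with a number 30 percentage points lower from compound 2 to compound 4 (beyond the scatter) across that change, whereas a number 6 percentage points lower from compound 1 to compound 4 (within the scatter) places it level with sulfanyl; among the four groups, the high read-out remains confined to chloro. Nothing measured here explains this difference.

Still open, from the compounds shown here alone, is whether the read-out depends on chloro itself, which bromo or fluoro at this carbon would test. A primary amine or monomethylamino would show whether other amines share the result for dimethylamino.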